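This account rests on a few compounds, and the source may have more. Where it says the series, first, only, none or still open, it means among the compounds named here.

compound 1 `N#Cc1ccc2c(c1)[C@@H](N1CCCC1=O)[C@H](O)C(CF)(CF)O2`: 85.1 nM
compound 2 `O=C1CCCN1[C@@H]1c2cc(C(F)(F)C(F)(F)F)ccc2OC(CF)(CF)[C@H]1O`: 6.31 nM
compound 3 `N#Cc1ccc2c(c1)C(N1CCCC1=O)=CC(CF)(CF)O2`: 102 nM

In a functional assay (aorta) with Rattus norvegicus as the target (a higher number here means that more compound is needed for the effect, a lower number that less compound is needed), compound 3 gives 102 nM, within the scatter of compound 1, while compound 2 lies lower than both, beyond the scatter. Compound 4 `O=C1CCCN1C1=CC(CF)(CF)Oc2ccc([N+](=O)[O-])cc21` differs from compound 3 in one place: nitro in place of cyano on an aromatic carbon. Within the data shown here, the only measured step at this aromatic carbon is a 13-fold lower number from compound 1 to compound 2 (1.13 log units; beyond the scatter), which is large. Among the measured compounds shown here, there, however, 1,1,2,2,2-pentafluoroethyl enters, not nitro, and no measured step has nitro entering. That step therefore bears only loosely, and no change beyond the scatter is expected in this assay. The expected step is a 1.5-fold lower number from compound 3 to compound 4 (0.16 log units; within the scatter). For compound 4 the estimated value is 70 nM, with an expected range of 20 nM to 250 nM.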

Compound 4, half-maximal effective concentration: 7.76 nM
For compound 4 the middle estimate is 9.0-fold (0.96 log units) above the measured one; measured number outside the range, below it.
By their numbers in this assay, from the lowest: compounds 2 and 4 (each within the scatter of the next); then compounds 1 and 3 (each within the scatter of the next).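

In this assay, nitro in place of cyano on this aromatic carbon gives a 13-fold lower number from compound 3 to compound 4 (1.12 log units; beyond the scatter) and so shows that a large step here is not confined to 1,1,2,2,2-pentafluoroethyl entering or to the core of compound 1. Cyano is the group leaving in both measured steps at this carbon. No measured evidence accounts for this step.

On these data alone, whether an amine or a carboxylic acid at this aromatic carbon would also lower the number remains open. Also open, as far as these compounds go, is how nitro behaves on the core of compound 1.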